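Same Atoms, New Connections: From Compound 2 to Compound 3

The compounds below may be only part of what the source reports. "The series", "measured", "known", "first", "only" and "open" are said of these compounds alone.

Of the compounds shown here, two have been measured in a functional assay on MCF7 cells (Homo sapiens) for antiproliferative activity, read by CellTiter-Glo, with a stated time of 5 days (a higher number here means a weaker inhibitor, a lower number a stronger inhibitor), so far.

Compound 1 (`CC/C(=C(/c1ccc(/C=C/C(=O)O)cc1)c1ccc2c(cnn2C)c1)c1ccc(F)cc1Cl`) gives 81 nM
Compound 2 (`CC/C(=C(/c1ccc(/C=C/C(=O)O)cc1)c1ccn2nccc2c1)c1ccccc1`) gives > 500 nM as a limit of the assay

Within the data shown here, compound 1 is the only one of the pair with an exact number. Compound 2 reads > 500 nM and this is a limit of the assay, not a number. Compound 2 thus stands at the limit of > 500 nM in this assay, at which 1 of the 2 values shown sits, and has no exact reading. Among the measured compounds shown here, compound 1 gives 81 nM, but it differs from compound 2 in more than one place, so the pair gives no single step to go by.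

Compound 3 (`CC/C(=C(/c1ccc(/C=C/C(=O)O)cc1)c1ccc2cncn2c1)c1ccccc1`) has the same atoms as compound 2, joined differently, and the change is a group of 9 heavy atoms (7 carbon, 2 nitrogen; one five-membered aromatic ring with 2 hetero atoms, one six-membered aromatic ring with 1 hetero atom) in place of a group of 9 heavy atoms (7 carbon, 2 nitrogen; one five-membered aromatic ring with 2 hetero atoms, one six-membered aromatic ring with 1 hetero atom), on a double-bonded chain carbon bound to an aromatic carbon and a double-bonded chain carbon and nothing else. For the measured compounds named here, no measured step shows what such a rearrangement does in this assay so no shift beyond the usual scatter is expected, in either direction. The expected step is a number no higher from compound 2 to compound 3 (the limit leaves the size open) and this is only an estimate. The estimate for compound 3 is 500 nM with an expected range from 150 nM to 1500 nM in this assay and a reading at the limit would fit that expectation.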

Compound 3, half-maximal inhibitory concentration: > 500 nM
Compound 3: a limit, no number (the forecaster's own chance of this, stated with the estimate: 55%); the middle value lies on the limit itself.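

In this assay, compound 3 gives a limit of the assay and no number, as compound 2 does, so no step between the two can be read; both share one reading: the limit of > 500 nM in this assay, at which 2 of the 3 values shown sit.

The compounds shown leave open whether this rearrangement of the same atoms changes the activity of compound 3 relative to compound 2 at all.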